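Working notes: ureido extension of compound 2 in the sulfonamide series

The source may report more compounds than this note shows. Statements on the series, on what has been measured and on what is new or still open speak of the compounds shown alone.

Measured so far in a functional assay on MCF7 cells (Homo sapiens) for inhibition, read by sulforhodamine B assay, with a stated time of 24 h; a higher number here means a weaker inhibitor, a lower number a stronger inhibitor:
compound 1, `N#Cc1c(-c2ccccc2)cn(-c2ccc(S(=O)(=O)Nc3nccs3)cc2)c1N`, gives 3490 nM
compound 2, `N#Cc1c(-c2ccccc2)cn(-c2ccc(S(=O)(=O)Nc3ccccn3)cc2)c1N`, gives 4600 nM
compound 3, `O=c1[nH]cnc2c1c(-c1ccccc1)cn2-c1ccc(S(=O)(=O)Nc2ccccn2)cc1`, gives 5320 nM

Compound 2 holds the second highest of the three numbers. Its nearest neighbour is compound 3, whose value lies within the scatter of that of compound 2; on the other side stands compound 1, and that step, a 1.3-fold higher number from compound 1 to compound 2 (0.12 log units; within the scatter), is within the scatter as well. The three measured values thus form one band in which no order can be read.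

Compound 4, `N#Cc1c(-c2ccccc2)cn(-c2ccc(S(=O)(=O)Nc3ccccn3)cc2)c1NC(N)=O`, differs from compound 2 by carbamoyl in place of hydrogen on a nitrogen on an aromatic ring. Going by the values given here, none of the measured steps touches this position. Among the compounds with values here, the one computed step, a 1.3-fold higher number from compound 1 to compound 2 (0.12 log units; within the scatter), concerns the sulfonamide nitrogen and stayed within the scatter; the values of compound 2 and compound 3, which differ in the core, also lie within the scatter of each other. The data therefore give no direction for this assay on this change, and the expected step is a 1.1-fold higher number from compound 2 to compound 4 (0.04 log units; within the scatter), that is, nothing beyond the scatter. Compound 4 is estimated at 5000 nM, with a range from 2000 nM to 13000 nM.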

Compound 4, half-maximal inhibitory concentration: 7340 nM
The estimate for compound 4 lay 1.5-fold (0.17 log units) below the measured number; measured number inside the range.
By their numbers in this assay, from the lowest: compounds 1, 2, 3 and 4 (each within the scatter of the next, the first and the last beyond it).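

In this assay the change from amino to ureido, the first at this nitrogen on an aromatic ring, gives a step that stays within the scatter (a 1.6-fold higher number from compound 2 to compound 4 (0.20 log units; within the scatter)), so the values of these two compounds cannot be told apart. The earlier comparisons shown here touched only the sulfonamide nitrogen and the core; this step shows that carbamoyl in place of hydrogen, which brings 3 heavy atoms and no ring to this position, also leaves the number within the scatter of compound 2. No measurement on hand accounts for this result at the level of any property of the group.

Going by these compounds, whether a different group on this nitrogen, such as an acetyl group, a methyl group or a longer chain ending in a carboxylic acid, would give a step beyond the scatter remains open. Also open, on these data alone, is whether the ureido group would give a similar step with the core of compound 3, or with 1,3-thiazol-2-yl on the sulfonamide nitrogen as in compound 1.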